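Changing the Amide Side Chain of Compound 3

The compounds below may be only part of what the source reports. "The series", "measured", "known", "first", "only" and "open" are said of these compounds alone.

In a functional assay on PC-3 cells (Homo sapiens) for antiproliferative activity, read by MTT assay, with a stated time of 48 h (a lower number here means a stronger inhibitor, a higher number a weaker inhibitor), compound 1 `CCOc1ccc(NC(=O)c2ccc(C(CC)(CC)c3ccc(OCCC(O)(CC)CC)c(C)c3)n2CC)cc1` reaches only a limit, > 50000 nM. In the same read-out, compound 2 `CCOC(=O)CN(C)C(=O)c1ccc(C(CC)(CC)c2ccc(OCCC(O)(CC)CC)c(C)c2)n1CC` gives 7140 nM, and compound 3 `CCC(C)C(NC(=O)c1ccc(C(CC)(CC)c2ccc(OCCC(O)(CC)CC)c(C)c2)n1CC)C(=O)O` gives 13800 nM. Among the compounds with values here, these are the only two numbers available, and they lie within the scatter of each other, as the comparison shows: a 1.9-fold higher number from compound 2 to compound 3 (0.29 log units; within the scatter).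

Compound 4 `CCn1c(C(=O)NC(C)CO)ccc1C(CC)(CC)c1ccc(OCCC(O)(CC)CC)c(C)c1` carries 1-(hydroxymethyl)ethyl in place of 1-carboxy-2-methylbutyl on an amide-type nitrogen. Within the data shown here, no measured compound carries the entering group, so the estimate rests on changes made in the same part of the molecule.

Two steps away from the 4-ethoxyphenyl amide bear on it: an at least 3.6-fold lower number from compound 1 to compound 3 (0.55 log units; beyond the scatter), and an at least 7.0-fold lower number from compound 1 to compound 2 (0.84 log units; beyond the scatter). Both start from a limit, so they give only a minimum size. The more direct guide is the pair without a ring in this side chain, where the groups differ considerably and yet the result is a 1.9-fold higher number from compound 2 to compound 3 (0.29 log units; within the scatter). On that basis, no step beyond the scatter is expected in this assay, and no direction is favoured. The expected step is a 1.2-fold lower number from compound 3 to compound 4 (0.06 log units; within the scatter). Compound 4 is estimated at 12000 nM, with an expected range of 4000 nM to 40000 nM.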

Compound 4, half-maximal inhibitory concentration: 7870 nM
Estimate against measurement, compound 4: 1.5-fold (0.18 log units) above; measured number inside the range.
By their numbers in this assay, from the lowest: compounds 2, 4 and 3 (each within the scatter of the next). At a limit, above all of these: compound 1.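

Replacing 1-carboxy-2-methylbutyl on the amide-type nitrogen with the smaller 1-(hydroxymethyl)ethyl, which carries no carboxyl group, does not separate the compounds in this assay: a 1.8-fold lower number from compound 3 to compound 4 (0.24 log units; within the scatter), and a 1.1-fold higher number from compound 2 to compound 4 (0.04 log units; within the scatter). Within the data shown here, compound 4 thus shows that the position tolerates a side chain of 4 heavy atoms as well as one of 8, so compounds 2, 3 and 4 cannot be told apart here, and an at least 6.3-fold lower number from compound 1 to compound 4 (0.80 log units; beyond the scatter) is the only new step beyond the scatter, a minimum size only. The value of compound 1 is a limit and not a number: the limit of > 50000 nM in this assay, at which 1 of the 4 values shown sits.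

The compounds shown leave open whether the separation from compound 1 belongs to the 4-ethoxyphenyl group as a whole or to its ethoxy part, which a plain phenyl or a 4-hydroxyphenyl on the same nitrogen would address. They also leave open whether an aminoethyl group, a longer alkyl chain or a free carboxylic acid on a short chain at this nitrogen would give a step beyond the scatter from compound 4.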